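Five-membered ring swap on the chloroaryl arm

The compounds below may be only part of what the source reports. "The series", "measured", "known", "first", "only" and "open" are said of these compounds alone.

Measured compounds:
compound 1 `Cn1nc2c(=O)n(CC3(O)CCN(Cc4ccc(-c5cnco5)cc4Cl)CC3)cnc2c1-c1ccc(CN)cc1`: in an assay on isolated protein for inhibition of ubiquitin carboxyl-terminal hydrolase 7 (Homo sapiens), with stated times of 30 min and 2 h (on this read-out lower numbers stand for stronger inhibition and higher numbers for weaker inhibition), compound 1 gives 71.6 nM
compound 2 `Cn1nc2c(=O)n(CC3(O)CCN(Cc4ccc(-c5ccco5)cc4Cl)CC3)cnc2c1-c1ccc(CNC=O)cc1`: in this assay compound 2 gives 20.9 nM
compound 3 `Cn1nc2c(=O)n(CC3(O)CCN(Cc4ccc(-c5ccco5)cc4Cl)CC3)cnc2c1-c1ccc(Cl)cc1`: in this assay compound 3 gives 143 nM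

Compound 1 sits second highest of the three numbers. Compound 3 lies within the scatter of compound 1, so no order between the two is claimed; compound 2 gives a lower number than compound 1, beyond the scatter. For the measured compounds named here, no step is computed for either of these pairs, so only their values are noted.

Compound 4 `Cn1nc2c(=O)n(CC3(O)CCN(Cc4ccc(-c5ccoc5)cc4Cl)CC3)cnc2c1-c1ccc(CN)cc1` differs from compound 1 in one place: furan-3-yl in place of 1,3-oxazol-5-yl on an aromatic carbon. Going by the values given here, the only measured step, a 6.8-fold higher number from compound 2 to compound 3 (0.84 log units; beyond the scatter), concerns the substituent on the other aryl ring and does not bear on this swap. Among the compounds with values here, compounds 2 and 3 carry a furan-2-yl ring, a different attachment, so no measured pair isolates the oxazole-to-furan exchange. In this assay the expectation for compound 4 is therefore a step no larger than the scatter, a 1.0-fold lower number from compound 1 to compound 4 (0.01 log units; within the scatter). Compound 4 is estimated at 70 nM, within 30 nM to 170 nM.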

Compound 4, half-maximal inhibitory concentration: 177 nM
The estimate for compound 4 lay 2.5-fold (0.40 log units) below the measured number; measured number above the stated range.
By their numbers in this assay, from the lowest: compound 2; then compounds 1, 3 and 4 (each within the scatter of the next, the first and the last beyond it).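

In this assay, for the compounds shown here, the five-membered ring on the chloroaryl arm is a position that registers on the read-out: furan-3-yl in place of 1,3-oxazol-5-yl gives a 2.5-fold higher number from compound 1 to compound 4 (0.39 log units; beyond the scatter) and is the first step read at this place, the earlier step having concerned only the other aryl ring. Ring size and heavy-atom count stay the same across this exchange, while one ring nitrogen and one hydrogen-bond acceptor leave, so the position responds even to a change of this limited kind. Nothing on hand accounts for the step.

Furan-2-yl appears only in compound 2 and compound 3, each with a different group on the other aryl ring, so its standing against furan-3-yl or 1,3-oxazol-5-yl remains open. Also open, as far as these compounds go, is how an amine or a carboxylic acid would read at this position.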